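Chloro in place of isopropoxy: a step against limits

The source may report more compounds than this note shows. Statements on the series, on what has been measured and on what is new or still open speak of the compounds shown alone.

Measured so far in an ADME assay on HepG2 cells (Homo sapiens) for cytotoxicity, read by luminescence, with a stated time of 72 h; a higher number here means that more compound is needed for the effect, a lower number that less compound is needed:
- compound 1 `CCOC(=O)c1c(-c2cccc(N(C)C)c2)[nH]c2cc(OC)ccc2c1=O`: > 21500 nM
- compound 2 `CCOC(=O)c1c(-c2cccc(-c3ccccc3)c2)[nH]c2cc(OC(C)C)ccc2c1=O`: > 21500 nM
- compound 3 `CCOC(=O)c1c(-c2cccc(OC)c2)[nH]c2cc(OC(C)C)ccc2c1=O`: > 21500 nM

Each of these entries is a limit of the assay and not a number. Compound 2 stands at > 21500 nM, which is a limit, so its true value cannot be placed more exactly. The same holds across the small set, which shows (the limit of > 21500 nM in this assay, at which 3 of the 3 values shown sit).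

Compound 4 `CCOC(=O)c1c(-c2cccc(-c3ccccc3)c2)[nH]c2cc(Cl)ccc2c1=O` keeps the rest of compound 2 and carries chloro in place of isopropoxy on an aromatic carbon. That carbon belongs to a six-membered aromatic ring of carbon only, part of a fused or bridged system of two rings.

For the measured compounds named here, the only measured step that starts from compound 2 is a step that the two limits leave unreadable from compound 2 to compound 3, with methoxy in place of phenyl on an aromatic carbon. It involves a different change and offers no size to carry over. Going by the values given here, no measured step replaces isopropoxy.

The expectation in this assay therefore rests on the limit of > 21500 nM in this assay, at which 3 of the 3 values shown sit: no step beyond the scatter is expected, no direction can be given, and another limit is the most likely report. For compound 4 the expected value is 30000 nM, with an estimated range of 14000 nM to 60000 nM. The estimated step is a step that the limit leaves unreadable from compound 2 to compound 4.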

Compound 4, half-maximal effective concentration: > 21500 nM
Compound 4: only a limit was reported (the forecaster's own chance of this, stated with the estimate: 80%); the middle value lies beyond the limit too.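

For the compounds shown here, compound 2 and compound 4 are both reported only as limits and not as numbers, so exchanging isopropoxy for chloro gives no step that can be read. The compounds shown leave open what concentration of any of them would produce the cytotoxic effect, because every result stands at the same limit: the limit of > 21500 nM in this assay, at which 4 of the 4 values shown sit.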